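The source may report more compounds than this note shows. Statements on the series, on what has been measured and on what is new or still open speak of the compounds shown alone.

Measured in a functional assay on CHO cells for antagonist activity at adenosine receptor A2b (Homo sapiens); on this read-out lower numbers stand for stronger inhibition and higher numbers for weaker inhibition:
compound 1 `Nc1ncnc2c1nc(-c1ccco1)n2CCCO` — 350 nM
compound 2 `CCCn1c(-c2ccco2)nc2c(N)ncnc21` — 250 nM
compound 3 `Cc1ccc(NC(=O)Nc2ncnc3c2nc(-c2ccco2)n3C)cc1` — > 30000 nM

Of the two numbers shown, compound 2 gives the lowest; compound 1 is nearest, with a 1.4-fold lower number from compound 1 to compound 2 (0.15 log units; within the scatter). For compound 3 the value in this assay is a limit of > 30000 nM in this assay, at which 1 of the 3 values shown sits, and not a number. Compound 4 `Cn1c(-c2ccco2)nc2c(N)ncnc21` differs from compound 2 by hydrogen in place of ethyl on a saturated chain carbon bound to an aromatic nitrogen. Within the data shown here, the only measured step on the same saturated chain is a 1.4-fold lower number from compound 1 to compound 2 (0.15 log units; within the scatter), which stayed within the scatter; no measured pair shortens the chain itself, so the step is read as small. For compound 4 in this assay a step of a 1.8-fold higher number from compound 2 to compound 4 (0.26 log units; within the scatter) is expected, not beyond the scatter. Compound 4 is therefore estimated at 450 nM, within 150 nM to 1400 nM.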

Compound 4, inhibition constant: 786 nM
For compound 4 the middle estimate is 1.7-fold (0.24 log units) below the measured one; measured number inside the range.
By their numbers in this assay, from the lowest: compounds 2 and 1 (each within the scatter of the next); then compound 4. At a limit, above all of these: compound 3.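

With the hydroxy change alone, a 1.4-fold lower number from compound 1 to compound 2 (0.15 log units; within the scatter) stayed within the scatter in this assay and the chain looked tolerant. Methyl in place of propyl reads differently: a 3.1-fold higher number from compound 2 to compound 4 (0.50 log units; beyond the scatter) and a 2.2-fold higher number from compound 1 to compound 4 (0.35 log units; beyond the scatter) both lie beyond the scatter, so chain length on the aromatic nitrogen does move the number, though modestly. This rests on compounds 1, 2 and 4 only, and none of them goes against it.

From the compounds shown here alone, whether a longer chain such as butyl, or an amine on the chain, would lower the number further stays open. Nothing shown gives a cause for these steps.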